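From 4-nitrophenyl to 2-bromophenyl: one unmeasured step

The source may hold more compounds than are shown below. What is called first, only, known or untested is meant among the compounds shown, and "the series" means these compounds.

- compound 1 `COc1ccc(COc2cc(O)c3c(=O)cc(C)oc3c2[C@H]2CCN(C)C[C@H]2O)cc1` gives 15% of inhibition
- compound 2 `Cc1cc(=O)c2c(O)c(CN3CCC(c4ccccc4)CC3)c(O)c([C@H]3CCN(C)C[C@H]3O)c2o1` gives 16% of inhibition
- compound 3 `Cc1oc2c([C@H]3CCN(C)C[C@H]3O)c(O)cc(O)c2c(=O)c1C(O)c1ccc([N+](=O)[O-])cc1` gives 2% of inhibition

In a functional assay on MIA PaCa-2 cells (Homo sapiens) for inhibition, read by MTT assay, with a stated time of 48 h, tested at 10 uM (a higher number here means more inhibition of growth at the concentration tested, a lower number less inhibition of growth), compound 3 stands lowest of the three, and the gaps up to compound 1 and to compound 2 both lie beyond the scatter.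

Compound 4 `Cc1oc2c([C@H]3CCN(C)C[C@H]3O)c(O)cc(O)c2c(=O)c1C(O)c1ccccc1Br` keeps the core of compound 3 and changes in one place (2-bromophenyl in place of 4-nitrophenyl on a saturated chain carbon bound to an aromatic carbon and an oxygen on a saturated carbon): 2-bromophenyl in place of 4-nitrophenyl on a saturated chain carbon bound to an aromatic carbon and an oxygen on a saturated carbon.

Among the compounds with values here, no two measured compounds differ in only one place, so the data do not show directly what this swap does. All three values are low, and compound 3 at 2% has little room to fall further. The estimated step runs a number 6 percentage points higher from compound 3 to compound 4 (within the scatter) in this assay and is expected to be a small rise, possibly none beyond the scatter. For compound 4 the expected value is 8% (estimated range 0% to 20%).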

Compound 4, percent growth inhibition at one concentration: 10%
Estimate against measurement, compound 4: 2 percentage points below; measured number inside the range.
By their numbers in this assay, from the lowest: compounds 3, 4, 1 and 2 (each within the scatter of the next, the first and the last beyond it).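

In this assay, within the data shown here, this pair gives the first direct reading of a change at this position: a number 8 percentage points higher from compound 3 to compound 4 (within the scatter). On a saturated chain carbon bound to an aromatic carbon and an oxygen on a saturated carbon, 4-nitrophenyl can therefore give way to 2-bromophenyl, a swap that removes the hydrogen-bond acceptors counted on the leaving group, without a change in growth inhibition beyond the usual scatter. No measurement of any property of these two groups bears on this result.

From the compounds shown here alone, both compounds carry a substituted phenyl ring at this place, so the effect of a different kind of group there, such as an amine or a carboxylic acid, remains open. Going by these compounds, the effect of moving the bromine to another ring position, or of using unsubstituted phenyl, also remains open.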